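Repositioning two methoxy groups on a chalcone-like series

The compounds below may be only part of what the source reports. "The series", "measured", "known", "first", "only" and "open" are said of these compounds alone.

Of the compounds shown here, three sharing one core have been tested in a functional assay on HCT-116 cells (Homo sapiens) for inhibition, read by sulforhodamine B assay, with a stated time of 72 h; a lower number here means a stronger inhibitor, a higher number a weaker inhibitor. Compound 1 `O=C(/C=C/c1cn(-c2ccccc2)nc1-c1cccnc1)c1ccccn1` gives 2100 nM, compound 2 `O=C(/C=C/c1cn(-c2ccccc2)nc1-c1cccnc1)c1cc[nH]c1` gives 7400 nM, and compound 3 `COc1ccc(C(=O)/C=C/c2cn(-c3ccccc3)nc2-c2cccnc2)cc1OC` gives 4300 nM. Compound 3 thus stands second highest of the three: the step of a 2.0-fold higher number from compound 1 to compound 3 (0.31 log units; beyond the scatter) lies beyond the scatter, while the step of a 1.7-fold lower number from compound 2 to compound 3 (0.24 log units; within the scatter) does not. Compound 4 `COc1ccc(OC)c(C(=O)/C=C/c2cn(-c3ccccc3)nc2-c2cccnc2)c1` differs from compound 3 only by 2,5-dimethoxyphenyl in place of 3,4-dimethoxyphenyl on a carbonyl carbon. Within the data shown here, no measured step swaps one dimethoxyphenyl for another; the steps from compound 1 involve different groups altogether, so they only show that changes at this carbonyl carbon have so far moved this assay modestly. The expectation for compound 4 is therefore a step of a 1.0-fold higher number from compound 3 to compound 4 (0.02 log units; within the scatter), within the scatter. Compound 4 is estimated at 4500 nM, with a range from 1500 nM to 13000 nM.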

Compound 4, half-maximal inhibitory concentration: 1000 nM
Estimate against measurement, compound 4: 4.5-fold (0.65 log units) above; the measured number lies below the stated range.
By their numbers in this assay, from the lowest: compound 4; then compound 1; then compounds 3 and 2 (each within the scatter of the next).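

In this assay the placement of the two methoxy groups on the ring matters by itself, with a 4.3-fold lower number from compound 3 to compound 4 (0.63 log units; beyond the scatter) even though both compounds hold the same atoms. With a 7.4-fold lower number from compound 2 to compound 4 (0.87 log units; beyond the scatter) and a 2.1-fold lower number from compound 1 to compound 4 (0.32 log units; beyond the scatter) the 2,5-dimethoxyphenyl group also outdoes both other groups on the carbonyl carbon, whereas 3,4-dimethoxyphenyl fell short of pyridin-2-yl. Nothing available explains this difference. Still open, from the compounds shown here alone, is whether both methoxy groups are needed, and how a phenyl ring carrying a single methoxy group, a hydroxyl group or an amine would compare.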